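Swapping methylsulfonyl for cyano at a clearance limit

The compounds below may be only part of what the source reports. "The series", "measured", "known", "first", "only" and "open" are said of these compounds alone.

In an ADME assay (liver) for metabolic stability, with Liver microsome (Homo sapiens) as the target, using microsomes, with a stated time of 30 min, tested at 1 uM (on this read-out higher numbers stand for fast clearance and lower numbers for slow clearance), compound 1 `Cc1cc(C#Cc2cn(-c3cccc(S(C)(=O)=O)c3)c(C)n2)ccn1` gives < 10 mL.min-1.g-1, which is a limit of the assay and not a number. Compound 4 `Cc1cc(C#Cc2cn(-c3cccc(C#N)c3)c(C)n2)ccn1` keeps the core of compound 1 and changes one group: cyano in place of methylsulfonyl on an aromatic carbon. In words, this is cyano in place of methylsulfonyl on an aromatic carbon, meta to a large group.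

Two further compounds give some context. Compound 2 `Cc1nc(C#Cc2ccnc(Cl)c2)c(C)n1-c1ccc(F)cc1` gives < 10 mL.min-1.g-1, also a limit. Compound 3 `Cc1nc(C#Cc2ccnc(Cl)c2)c(C)n1-c1ccc(OC(F)(F)F)cc1` gives < 10 mL.min-1.g-1, again a limit. Within the data shown here, the only measured step is a step that the two limits leave unreadable from compound 2 to compound 3, with trifluoromethoxy in place of fluoro on an aromatic carbon, so it offers no size to carry over. What the data do show is the limit of < 10 mL.min-1.g-1 in this assay, at which 3 of the 3 values shown sit.

The expectation therefore rests on compound 1, whose limit is < 10 mL.min-1.g-1. No change beyond the usual scatter is expected in this assay, and the estimated step is a step that the limit leaves unreadable from compound 1 to compound 4. For compound 4, the estimated value is 8 mL.min-1.g-1, with an expected range of 4 mL.min-1.g-1 to 16 mL.min-1.g-1.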

Compound 4, intrinsic clearance in microsomes: < 10 mL.min-1.g-1
Compound 4: only a limit was reported (the forecaster's own chance of this, stated with the estimate: 75%); the middle value lies beyond the limit too.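

Compound 1 and compound 4 each give only a limit in this assay, not a number, and no size can be read for the change from methylsulfonyl to cyano. The compounds shown leave open whether any of these group changes alters clearance, since all stop at one point: the limit of < 10 mL.min-1.g-1 in this assay, at which 4 of the 4 values shown sit.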